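Propanoyl to a small nitrogen–sulfur group on the shared core

The source may hold more compounds than are shown below. What is called first, only, known or untested is meant among the compounds shown, and "the series" means these compounds.

The measured compounds, with their values in a functional assay (aorta) with Rattus norvegicus as the target; on this read-out lower numbers stand for lower potency and higher numbers for higher potency (the scale is a negative logarithm):

compound 1 `CCC(=O)c1ccc2c(c1)C(n1ccccc1=O)=CC(C)(C)O2` gives 6.63
compound 2 `CC1(C)C=C(n2ccccc2=O)c2cc(OCC(=O)c3ccccc3)ccc2O1` gives 5.05
compound 3 `CC1(C)C=C(n2ccccc2=O)c2cc(OC(=O)Nc3ccc(F)cc3)ccc2O1` gives 5.3

Compound 1 stands highest of the three; compound 3 is nearest, and compound 2 furthest, both beyond the scatter from compound 1. Going by the values given here, the only step between measured compounds that differ in one place is a number 0.25 log units higher from compound 2 to compound 3 (within the scatter), a change of (4-fluorophenyl)carbamoyl in place of benzoylmethyl on an oxygen on an aromatic ring, and it lies within the scatter.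

Compound 4 `CC1(C)C=C(n2ccccc2=O)c2cc(C(=N)S)ccc2O1` is not yet measured. It differs from compound 1 in this way: a group of 3 heavy atoms (1 carbon, 1 nitrogen, 1 sulfur; no ring) in place of a group of 4 heavy atoms (3 carbon, 1 oxygen; no ring), on an aromatic carbon. The entering group carries two hydrogen-bond donors where propanoyl had none. Among the compounds with values here, no measured step touches this position, so nothing among the measured compounds tells how the change will play out; the one step known concerns a substituent on an oxygen and shifted the number little.

Within the data shown here, with no step to lean on, a modest expectation for compound 4 is a value near compound 1, with wide uncertainty: the estimate is 6.4, between 5.6 and 7.2. This expectation corresponds to an estimated step of a number 0.23 log units lower from compound 1 to compound 4 (within the scatter).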

Compound 4, logarithm of the reciprocal of the active concentration, log(1/C): 6.21
Beside the measured number, compound 4's estimate is 0.19 log units above it; the range from low to high includes it.
By their numbers in this assay, from the lowest: compounds 2 and 3 (each within the scatter of the next); then compound 4; then compound 1.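

The earlier compounds shown here held no step at this aromatic carbon, and in this assay the exchange of propanoyl for the smaller group of 3 heavy atoms, with its carbon, nitrogen and sulfur, gives a number 0.42 log units lower from compound 1 to compound 4 (beyond the scatter), a modest but real change. Compound 4 still reaches 6.21 with a group that has no propanoyl chain and carries hydrogen-bond donors where propanoyl carries none, so in this one pair propanoyl is not required for activity on this read-out. No measurement of any property of the two groups accompanies the step, and the pair offers no explanation for it.

Going by these compounds, whether the number at this aromatic carbon would hold, fall or rise with an amine, a carboxylic acid or a longer chain such as butanoyl stays open. The compounds shown also leave unresolved whether the step follows from the shorter group, its nitrogen or its sulfur, a question that a primary carboxamide or a thioamide at the same carbon could help to separate.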